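Swapping a bromo for thiophen-2-yl on the shared core

This account rests on a few compounds, and the source may have more. Where it says the series, first, only, none or still open, it means among the compounds named here.

Measured so far, in a functional assay on MOLT-4 cells (Homo sapiens) for inhibition, read by sulforhodamine B assay, with a stated time of 48 h, tested at 10 uM; a lower number here means less inhibition, a higher number more inhibition at the concentration tested (going by the name of the read-out):
- compound 1 `Brc1cn2ccnc2c(-c2ccc3ncn(C4CCCCC4)c3c2)n1` gives 26.3%
- compound 2 `c1ccc(-c2cn3ccnc3c(-c3ccc4ncn(C5CCCCC5)c4c3)n2)cc1` gives 67.7%
- compound 3 `Brc1ccc(-c2cn3ccnc3c(-c3ccc4ncn(C5CCCCC5)c4c3)n2)cc1` gives 20.4%

Compound 1 stands second highest of the three numbers. Its nearest neighbour is compound 3, reached by a number 5.9 percentage points lower from compound 1 to compound 3 (within the scatter), a change that stays within the scatter. Its furthest neighbour is compound 2, reached by a number 41.4 percentage points higher from compound 1 to compound 2 (beyond the scatter), a large step beyond the scatter. Compound 4 `c1csc(-c2cn3ccnc3c(-c3ccc4ncn(C5CCCCC5)c4c3)n2)c1` is not yet measured. It differs from compound 1 in one place: thiophen-2-yl in place of bromo on an aromatic carbon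

The two measured steps from compound 1 both replace bromo with an aromatic ring. Phenyl gave the large rise a number 41.4 percentage points higher from compound 1 to compound 2 (beyond the scatter), whereas 4-bromophenyl gave a number 5.9 percentage points lower from compound 1 to compound 3 (within the scatter), no real change. Thiophen-2-yl, an unsubstituted five-membered aromatic ring with one hetero atom, is closer in kind to phenyl than to 4-bromophenyl, so a rise beyond the scatter is expected for compound 4, though its size is uncertain because only a number 41.4 percentage points higher from compound 1 to compound 2 (beyond the scatter) points the way. The expected step is a number 28.7 percentage points higher from compound 1 to compound 4 (beyond the scatter). Compound 4 is therefore estimated at 55%, in the range 25% to 80%.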

Compound 4, a percentage reported as inhibition, at one concentration (the size of the read-out at that concentration, not a potency): 30.8%
Beside the measured number, compound 4's estimate is 24.2 percentage points above it; measured number inside the range.
By their numbers in this assay, from the lowest: compounds 3, 1 and 4 (each within the scatter of the next, the first and the last beyond it); then compound 2.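

In this assay, swapping phenyl for thiophen-2-yl gives a number 36.9 percentage points lower from compound 2 to compound 4 (beyond the scatter), so the gain seen with phenyl does not carry over to this five-membered aromatic ring. Thiophen-2-yl in place of bromo gives a number 4.5 percentage points higher from compound 1 to compound 4 (within the scatter), which shows that an unsubstituted aromatic ring at this position is not enough on its own for a high number, and phenyl remains the only group here that stands apart from all the others. Thiophen-2-yl in place of 4-bromophenyl gives a number 10.4 percentage points higher from compound 3 to compound 4 (beyond the scatter), a modest separation between two groups that each lie within the scatter of bromo. On these data alone, what an amine or a carboxylic acid on the phenyl ring would do at this position remains open. Nothing available explains why phenyl and thiophen-2-yl differ so widely.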